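A few compounds are considered here, and "the series" means these few. Any claim that something is new, unique, unknown or untested is made for them only; others in the source may bear on it.

Working notes on the series. For the measured compounds named here, compound 1 `C=C(C)C(=O)c1ccc(OCc2nc(C)no2)cc1C` gives 5000 nM in an assay on HL-60 cells for inhibition of glutathione S-transferase P (Homo sapiens) (on this read-out lower numbers stand for stronger inhibition and higher numbers for weaker inhibition), and stands at the highest of the three numbers measured so far. Compound 2 `C=C(C)C(=O)c1ccc(OCc2nc(-c3ccccc3)no2)cc1C` gives 1970 nM in this assay, and compound 3 `C=C(C)C(=O)c1ccc(OCc2nc(-c3ccc(F)cc3)no2)cc1C` gives 3500 nM. The three measured steps all concern the methyl replaced by phenyl or 4-fluorophenyl, or the fluoro on that phenyl: a 2.5-fold lower number from compound 1 to compound 2 (0.40 log units; beyond the scatter); a 1.4-fold lower number from compound 1 to compound 3 (0.15 log units; within the scatter); a 1.8-fold higher number from compound 2 to compound 3 (0.25 log units; within the scatter).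

Compound 4 `C=C(C)C(=O)c1ccc(OCc2nc(C)no2)cc1Br` differs from compound 1 by bromo in place of methyl on an aromatic carbon. This change sits on a different part of the shared core than any measured step, on the six-membered aromatic ring of carbon only, ortho to the (1-methylethenyl)carbonyl group. Going by the values given here, no measured step therefore bears on it, and there is no basis for a directional expectation. The expectation is a step within the scatter, no change at the digits printed from compound 1 to compound 4 (within the scatter). Compound 4 is estimated at 5000 nM in this assay, with a range from 2000 nM to 12500 nM.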

Compound 4, half-maximal inhibitory concentration: 3200 nM
Compound 4: middle estimate off by 1.6-fold (0.19 log units), on the high side; the measured number falls inside the stated range.
By their numbers in this assay, from the lowest: compounds 2, 4, 3 and 1 (each within the scatter of the next, the first and the last beyond it).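

In this assay, bromo in place of methyl on the aromatic carbon ortho to the (1-methylethenyl)carbonyl group gives a 1.6-fold lower number from compound 1 to compound 4 (0.19 log units; within the scatter). This is the first view of this position in the compounds shown, and compound 1 and compound 4 cannot be told apart here, so this position accepts either group without a readable difference. Nothing measured on these compounds accounts for this result.

On these data alone, it remains open whether an amine, a methoxy group or plain hydrogen at this position would read the same, and whether bromo would behave alike on compound 2, which carries phenyl in place of the methyl that compound 1 keeps on its other aromatic ring. The compounds shown also leave open how much the (1-methylethenyl)carbonyl group itself contributes.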